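Swapping an aryl substituent on a fused thiophene core

This account rests on a few compounds, and the source may have more. Where it says the series, first, only, none or still open, it means among the compounds named here.

Compound 1 `CNc1nc(NCCCN(C)C)c2sc(-c3ccc(C(C)=O)cc3)cc2n1` is examined in a physicochemical assay for lipophilicity, read by HPLC, at pH 7.4 (a higher number here means a more lipophilic compound, a lower number a more polar compound), where compound 1 gives 2.9. Among the three measured compounds it stands lowest. Among the measured compounds shown here, compound 2 `CNc1nc(NCCCN(C)C)c2sc(-c3ccc(N4CCNCC4)cc3)cc2n1` gives 3.5, and the only step that links two measured compounds, a number 0.60 log units higher from compound 1 to compound 2 (beyond the scatter), is a modest rise that lies beyond the scatter. For the measured compounds named here, compound 3 `CNc1nc(NCCCN(C)C)c2sc(-c3ccc(C(F)(F)F)cc3Cl)cc2n1` gives 4.5, the highest of the three, and no single-point step connects it to compound 1.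

Compound 4 `CNc1nc(NCCCN(C)C)c2sc(-c3cccc(C#N)c3)cc2n1` is not yet measured. It differs from compound 1 in one place: 3-cyanophenyl in place of 4-acetylphenyl on an aromatic carbon. Going by the values given here, the one measured step concerns a piperazin-1-yl entering for an acetyl, so it bears on this change only in showing that a single substituent swap on that aromatic ring can move the number by a modest amount. Among the compounds with values here, no measured step involves a cyanophenyl or a change in the ring position of a substituent. The groups that leave and enter each carry one hydrogen-bond acceptor and no charge, so the account expects no step beyond the scatter, a number 0.10 log units higher from compound 1 to compound 4 (within the scatter), in either direction. Compound 4 is therefore estimated at 3, with a range from 2.6 to 3.4.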

Compound 4, distribution coefficient: 2.9
Compound 4: the middle estimate sits 0.10 log units above what was measured; the measured number falls inside the stated range.
By their numbers in this assay, from the lowest: compounds 1 and 4 (each within the scatter of the next); then compound 2; then compound 3.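

In this assay, putting 3-cyanophenyl in place of 4-acetylphenyl on the aromatic carbon next to the ring sulfur gives no change at the digits printed from compound 1 to compound 4 (within the scatter). The earlier step, a number 0.60 log units higher from compound 1 to compound 2 (beyond the scatter), showed that a swap at this place can carry the number beyond the scatter, whereas this one shows that not every swap does: a different group, set at a different point on the phenyl ring, leaves compound 4 within the scatter of compound 1. No measurement offered here bears on why this exchange leaves the reading where it is.

The nitrile and its point of attachment on the phenyl ring arrive together in compound 4, and the compounds shown do not separate the two, leaving open whether a 4-cyanophenyl or a 3-acetylphenyl would read the same. Also open, as far as these compounds go, is how this assay would respond at this place to a phenyl ring carrying a carboxylic acid, a morpholine or a longer chain ending in an amine.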